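Swapping the Terminal Heteroaryl on a Shared Core

A few compounds are considered here, and "the series" means these few. Any claim that something is new, unique, unknown or untested is made for them only; others in the source may bear on it.

Measured compounds:
compound 1 `CCC(C)(C)Cc1c[nH]c(CCc2ccc(-c3cccc(N)n3)cc2)n1` gives 119 nM in a functional assay on HEK293 cells for agonist activity at Bombesin receptor subtype-3 (Mus musculus), read by luminescence and calcium flux, with a stated time of 10 min; a higher number here means that more compound is needed for the effect, a lower number that less compound is needed
compound 2 `CCC(C)(C)Cc1c[nH]c(CCc2ccc(-c3ccncc3)cc2)n1` gives 103 nM in this assay
compound 3 `CCC(C)(C)Cc1c[nH]c(CCc2ccc(-c3csnn3)cc2)n1` gives 109 nM in this assay

Compound 3 sits among three numbers that barely differ from one another. Its nearest neighbour is compound 2, and the step between them was a 1.1-fold higher number from compound 2 to compound 3 (0.02 log units; within the scatter); its furthest neighbour is compound 1, and that step was a 1.1-fold lower number from compound 1 to compound 3 (0.04 log units; within the scatter). The remaining step, a 1.2-fold lower number from compound 1 to compound 2 (0.06 log units; within the scatter), was likewise within the scatter. Every exchange of the terminal heteroaryl group measured so far, whether it carried an amino group or not, whether it was a six-membered or a five-membered ring, left the number in this assay essentially where it was.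

Compound 4 `CCC(C)(C)Cc1c[nH]c(CCc2ccc(-c3cccnc3)cc2)n1` continues this series. It differs from compound 3 as follows: pyridin-3-yl in place of 1,2,3-thiadiazol-4-yl on an aromatic carbon

All three measured steps bear on this change, since each of them also swaps one heteroaryl group for another at the same aromatic carbon, and none of them moved the number beyond the scatter. The expectation for compound 4 in this assay is therefore a step of a 1.0-fold higher number from compound 3 to compound 4 (0.00 log units; within the scatter), with no direction that could be told apart from repeat measurements. Compound 4 is estimated at 110 nM, with a range from 55 nM to 220 nM.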

Compound 4, half-maximal effective concentration: 97 nM
Compound 4: middle estimate off by 1.1-fold (0.05 log units), on the high side; the measured number falls inside the stated range.
By their numbers in this assay, from the lowest: compounds 4, 2, 3 and 1 (each within the scatter of the next).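

For the compounds shown here, compound 4 adds the first pair that differs only in where the ring nitrogen lies within a pyridine, pyridin-3-yl against pyridin-4-yl, and in this assay that exchange gave a 1.1-fold lower number from compound 2 to compound 4 (0.03 log units; within the scatter). Replacing a five-membered aromatic ring with 3 hetero atoms by a six-membered aromatic ring with 1 hetero atom, both on the same aromatic carbon para to a large group, gave a 1.1-fold lower number from compound 3 to compound 4 (0.05 log units; within the scatter), so neither ring size nor the count of hetero atoms separates these compounds at this position. Removing the amino group along with changing the attachment of the pyridine gave a 1.2-fold lower number from compound 1 to compound 4 (0.09 log units; within the scatter), which extends the same picture to all four terminal groups, since every step among them lies within the scatter.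

The data offer no measured property or other independent finding that would explain why these exchanges leave the number in place. Still open, as far as these compounds go, is whether this tolerance extends beyond aromatic heterocycles, for instance to a carboxylic acid, a morpholine or a longer chain ending in an amine on the same aromatic carbon.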